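Cytotoxicity of a Side-Chain Variant on the Shared Core

A few compounds are considered here, and "the series" means these few. Any claim that something is new, unique, unknown or untested is made for them only; others in the source may bear on it.

The compounds compared here share one core and differ only in the chain attached to an aromatic nitrogen. Compound 1 `CC(C)CCn1nc(-c2cccs2)c(O)c(C2=NS(=O)(=O)c3cc(NS(=O)(=O)C4CC4)ccc3N2)c1=O` carries a 3-methylbutyl chain there. In an ADME assay on Huh-7 cells (Homo sapiens) for cytotoxicity, with a stated time of 72 h (on this read-out lower numbers stand for higher toxicity in this test and higher numbers for lower toxicity in this test), compound 1 shows only a limit of the test, > 1000 nM. Compound 2 `CCCC(C)n1nc(-c2cccs2)c(O)c(C2=NS(=O)(=O)c3cc(NS(C)(=O)=O)ccc3N2)c1=O` carries a 1-methylbutyl chain at the same nitrogen. In this assay compound 2 likewise shows only a limit, > 33000 nM. Going by the values given here, both measured results are limits rather than numbers, so they reveal no ordering between compound 1 and compound 2, and no step between them can be drawn.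

Compound 3 `CS(=O)(=O)Nc1ccc2c(c1)S(=O)(=O)N=C(c1c(O)c(-c3cccs3)nn(CCC3CCCC3)c1=O)N2` is the unmeasured compound that follows from compound 2 by one change: 2-cyclopentylethyl in place of 1-methylbutyl on an aromatic nitrogen. Among the compounds with values here, with no measured step on record, the expected change in this assay from compound 2 to compound 3 is none beyond the scatter, a step that the limit leaves unreadable from compound 2 to compound 3. Compound 3 is therefore expected to give about 40000 nM in this assay, with a likely range from 10000 nM to 120000 nM, and the result will most probably again be reported as a limit.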

Compound 3, half-maximal cytotoxic concentration: > 1000 nM
Compound 3: only a limit was reported (the forecaster's own chance of this, stated with the estimate: 70%); the middle value is on the limit's open side.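

In this assay, going by these compounds alone, compound 2 and compound 3 are both reported only as limits, not numbers, and no step between them can be read. The compounds shown leave open whether 2-cyclopentylethyl in place of 1-methylbutyl changes cytotoxicity at all, and by how much.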